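The source may hold more compounds than are shown below. What is called first, only, known or untested is meant among the compounds shown, and "the series" means these compounds.

Three carbamates built on one shared core have been tested in a functional assay on MCF7 cells (Homo sapiens) for cytotoxicity, read by MTT assay, with a stated time of 72 h; a higher number here means that more compound is tolerated, a lower number that less compound is tolerated. Compound 1 `CCCOC(=O)Nc1ccc([Se]C#N)cc1` gives 67500 nM. Compound 2 `CCCCOC(=O)Nc1ccc([Se]C#N)cc1` gives 59700 nM, and compound 3 `CC(C)COC(=O)Nc1ccc([Se]C#N)cc1` gives 73000 nM. As written, the number for compound 3 is the largest of the three, yet the step of a 1.1-fold higher number from compound 1 to compound 3 (0.03 log units; within the scatter) and the step of a 1.2-fold higher number from compound 2 to compound 3 (0.09 log units; within the scatter) both fall within the scatter of repeated measurements, so the three compounds cannot really be told apart.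

The new compound 4 `C=CCOC(=O)Nc1ccc([Se]C#N)cc1` differs from compound 3 in one place: vinyl in place of isopropyl on a saturated chain carbon bound to an oxygen next to a carbonyl group. Every earlier step also changed only the chain on the saturated carbon bound to the oxygen next to the carbonyl group. The step of a 1.1-fold lower number from compound 1 to compound 2 (0.05 log units; within the scatter), the step of a 1.1-fold higher number from compound 1 to compound 3 (0.03 log units; within the scatter) and the step of a 1.2-fold higher number from compound 2 to compound 3 (0.09 log units; within the scatter) all stayed within the scatter, so lengthening or branching that chain has so far left the read-out essentially unchanged. Swapping isopropyl for vinyl is a change of similar scale at the same place, and no step beyond the scatter is expected; the expected step is a 1.1-fold lower number from compound 3 to compound 4 (0.05 log units; within the scatter). Compound 4 is therefore expected to give about 65000 nM in this assay, with a likely range from 35000 nM to 120000 nM.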

Compound 4, concentration lethal to 50% of the cells: 71200 nM
Compound 4: the middle estimate sits 1.1-fold (0.04 log units) below what was measured; the measured number falls inside the stated range.
By their numbers in this assay, from the lowest: compounds 2, 1, 4 and 3 (each within the scatter of the next).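

Within the data shown here, compound 4 is the first to carry a double bond outside aromatic rings at the saturated chain carbon bound to an oxygen next to a carbonyl group, and in this assay it cannot be told apart from the three compounds with fully saturated chains (a 1.0-fold lower number from compound 3 to compound 4 (0.01 log units; within the scatter); a 1.2-fold higher number from compound 2 to compound 4 (0.08 log units; within the scatter); a 1.1-fold higher number from compound 1 to compound 4 (0.02 log units; within the scatter)). The earlier compounds shown here showed only that lengthening or branching a saturated chain here left the read-out within the scatter, and this result extends that observation to an allyloxy group in place of isobutoxy, with one heavy atom fewer in the group that enters than in the isopropyl that leaves. Nothing available accounts for this lack of a measurable difference.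

On these data alone, all four chains are short and made only of carbon and hydrogen, so it remains open whether a much longer chain, a benzyl group or a chain ending in an amine or a carboxylic acid would give a step beyond the scatter. As far as these compounds go, whether the same tolerance holds for changes elsewhere on the shared core, or in other cell lines, also stays open.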